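Ester for chloro on the benzyl ether arm

A few compounds are considered here, and "the series" means these few. Any claim that something is new, unique, unknown or untested is made for them only; others in the source may bear on it.

Compound 2 `Clc1ccc(COc2ccc(OCCOCCNC3CCCCC3)cc2)cc1` gives the lowest number of the three measured in a functional assay on SK-OV-3 cells (Homo sapiens) for inhibition, read by CCK-8 assay, with a stated time of 70 h (a lower number here means a stronger inhibitor, a higher number a weaker inhibitor), at 2650 nM. Within the data shown here, compound 1 `Clc1ccc(COc2ccc(OCCOCCNC3CCCC3)cc2)cc1` gives 7670 nM, and the step of a 2.9-fold lower number from compound 1 to compound 2 (0.46 log units; beyond the scatter) is the only single change measured so far. Compound 3 `c1ccc(COc2ccccc2OCCOCCNC2CCCC2)cc1` gives 40700 nM; it differs from compound 1 in more than one place, so no single step can be read from it. Compound 4 `COC(=O)c1ccc(COc2ccc(OCCOCCNC3CCCCC3)cc2)cc1` carries methoxycarbonyl in place of chloro on an aromatic carbon. Among the measured compounds shown here, no measured step bears on this change; the one step known concerns the amine substituent, not the aromatic ring. The expectation for compound 4 therefore rests on compound 2 alone, with a wide range, and the step of a 2.3-fold higher number from compound 2 to compound 4 (0.35 log units; beyond the scatter) is estimated as a modest weakening. Compound 4 is expected near 6000 nM, between 1500 nM and 25000 nM.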

Compound 4, half-maximal inhibitory concentration: 6220 nM
For compound 4 the middle estimate is 1.0-fold (0.02 log units) below the measured one; low and high end bracket the measured number.
By their numbers in this assay, from the lowest: compound 2; then compounds 4 and 1 (each within the scatter of the next); then compound 3.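

The aromatic carbon para to a large group on the benzyl ether arm proves open to change: in this assay, methoxycarbonyl in place of chloro gives a 2.3-fold higher number from compound 2 to compound 4 (0.37 log units; beyond the scatter) and activity stays measurable with the larger group. Among these compounds, the earlier step concerned only the amine substituent, so this is the first reading at this position. Nothing at hand accounts for the size of this step.

Open, from the compounds shown here alone, is whether a carboxylic acid, an amide or a nitrile at this position would give a lower or higher number. Also open, going by these compounds, is whether the same change would behave alike with the cyclopentyl amine of compound 1.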